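From chloro to iodo at the assay limit

A few compounds are considered here, and "the series" means these few. Any claim that something is new, unique, unknown or untested is made for them only; others in the source may bear on it.

In an ADME assay on RAW264.7 cells (Mus musculus) for cytotoxicity, read by MTT assay, with a stated time of 24 h (on this read-out higher numbers stand for lower toxicity in this test and lower numbers for higher toxicity in this test), compound 1 (`O=C(Nc1ccc(Cl)cc1F)c1ccccc1OCc1ccc(F)cc1F`) gives > 40000 nM as a limit of the assay, not a number. Compound 2 (`COc1ccc(C(=O)Nc2ccc(Cl)cc2F)c(OCc2ccc(F)cc2F)c1`) gives > 40000 nM as a limit too. Compound 3 (`O=C(Nc1ccc(I)cc1F)c1ccccc1OCc1ccc(F)cc1F`) carries iodo in place of chloro on an aromatic carbon. Among the measured compounds shown here, the one measured step (a step that the two limits leave unreadable from compound 1 to compound 2) is a different change with no size to carry over, so no shift beyond the scatter is expected in this assay in either direction. The expected change is small (a number no higher from compound 1 to compound 3 (the limit leaves the size open)). Compound 3 is estimated at 40000 nM as a middle value (expected range from 15000 nM to 80000 nM).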

Compound 3, half-maximal cytotoxic concentration: 32600 nM
Beside the measured number, compound 3's estimate is 1.2-fold (0.09 log units) above it; low and high end bracket the measured number.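

In this assay, putting iodo in place of chloro on this aromatic carbon gives an at least 1.2-fold lower number from compound 1 to compound 3 (0.08 log units; that floor lies within the scatter). Compound 3 is the first compound shown that gives a number rather than a limit. How large the change really is stays unknown, because the value of compound 1 is only a limit: the limit of > 40000 nM in this assay, at which 2 of the 3 values shown sit.

Only this one swap is shown at this position, so what bromo, an amine or a carboxylic acid would give there remains open. Also open, on these data alone, is whether iodo and the methoxy group of compound 2 would read differently together on the shared core.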